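This account rests on a few compounds, and the source may have more. Where it says the series, first, only, none or still open, it means among the compounds named here.

Measured so far:
Compound 1 `COc1ccc(S(=O)(=O)N2CCc3cccc(-c4ccc(N(C)C)cc4)c32)cc1` (556 nM)
Compound 2 `COc1ccc(S(=O)(=O)N2CCc3cccc(-c4c(F)c(F)c(F)c(F)c4F)c32)cc1` (4760 nM)
Compound 3 `COc1ccc(S(=O)(=O)n2ccc3cccc(-c4ccc(F)cc4)c32)cc1` (212 nM)

In a functional assay on NCI-H460 cells (Homo sapiens) for inhibition, with a stated time of 72 h (on this read-out lower numbers stand for stronger inhibition and higher numbers for weaker inhibition), compound 1 (556 nM) holds the middle place of the three. Its value is the second highest, higher than that of compound 3 (212 nM) and lower than that of compound 2 (4760 nM), and both gaps lie beyond the scatter.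

Compound 4 `COc1ccc(S(=O)(=O)N2CCc3cccc(-c4ccc(C#N)cc4)c32)cc1` keeps the core of compound 1 and carries cyano in place of dimethylamino on an aromatic carbon, para to a large group (cyano in place of dimethylamino on an aromatic carbon).

Going by the values given here, no measured pair differing in one place is available, so the data offer no direct guide to this change. The expected step of a 1.1-fold higher number from compound 1 to compound 4 (0.03 log units; within the scatter) is therefore small, within the scatter in this assay, with no firm direction. The uncertainty stays wide, as the measured values run from compound 3 (212 nM) to compound 2 (4760 nM). Compound 4 is estimated at 600 nM (expected range 150 nM to 2400 nM).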

Compound 4, half-maximal inhibitory concentration: 29.5 nM
The estimate for compound 4 lay 20-fold (1.31 log units) above the measured number; measured number below the stated range.
By their numbers in this assay, from the lowest: compound 4; then compound 3; then compound 1; then compound 2.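

In this assay, the shared core held fixed, the change from dimethylamino to cyano on an aromatic carbon, para to a large group, gives a 19-fold lower number from compound 1 to compound 4 (1.28 log units; beyond the scatter). Going by these compounds alone, this first pair differing in one place shows that the read-out is highly sensitive to the group at this position, a sensitivity the earlier compounds, which differ in more than one place, could not isolate. Nothing measured on these groups accounts for the size of this step.

One pair cannot separate what cyano adds from what the loss of dimethylamino removes. As far as these compounds go, it remains open whether a carboxylic acid, a primary amide or a methoxy group at this position would fall nearer compound 4 or compound 1, and whether the same change would have a similar effect on the core of compound 3.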